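The source may report more compounds than this note shows. Statements on the series, on what has been measured and on what is new or still open speak of the compounds shown alone.

Measured compounds:
Compound 1, `O=[N+]([O-])c1cccc(/N=N/N2CCCCC2)c1`: in an ADME assay on BHK-21 cells (Mesocricetus auratus) for cytotoxicity, read by MTT assay, with a stated time of 96 h (on this read-out lower numbers stand for higher toxicity in this test and higher numbers for lower toxicity in this test), compound 1 gives > 100000 nM, which is a limit of the assay and not a number.
Compound 2, `FC(F)(F)c1cccc(N(C[C@@H]2CCCN3CCCC[C@H]23)/N=N/c2ccccc2)c1`: in this assay compound 2 gives 40000 nM.
Compound 3, `Fc1ccc(F)c(/N=N/Nc2cc(F)ccc2F)c1`: in this assay compound 3 gives > 100000 nM, again a limit of the assay rather than a number.

For the measured compounds named here, compound 2 thus carries the only number in this assay; the other two values of the set sit at the limit of > 100000 nM in this assay, at which 2 of the 3 values shown sit. Going by the values given here, no pair of measured compounds differs in a single place, so no measured step is available to lean on, and whatever is said of the next compound rests on the single number of compound 2 and on the structural change alone.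

Compound 4, `CN(C)CCCN(/N=N/c1ccccc1)c1cccc(C(F)(F)F)c1`, differs from compound 2 in one place: a group of 5 heavy atoms (4 carbon, 1 nitrogen; no ring) in place of a group of 10 heavy atoms (9 carbon, 1 nitrogen; 2 six-membered non-aromatic rings with 1 hetero atom each), on a saturated chain carbon bound to a nitrogen on an aromatic ring. Among the compounds with values here, with no measured step to compare against, the expectation is a step of modest size toward lower toxicity in this assay, or none beyond the scatter, with a real chance that the assay reports only a limit. Compound 4 is estimated at 80000 nM in this assay, expected to lie between 30000 nM and 200000 nM. The step this estimate means is expected to be a 2.0-fold higher number from compound 2 to compound 4 (0.30 log units; within the scatter).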

Compound 4, half-maximal cytotoxic concentration: 49000 nM
For compound 4 the middle estimate is 1.6-fold (0.21 log units) above the measured one; measured number inside the range.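

At the place on a saturated chain carbon bound to a nitrogen on an aromatic ring, exchanging the group with 2 six-membered non-aromatic rings and 2 defined stereocentres for 2-(dimethylamino)ethyl reads in this assay as a 1.2-fold higher number from compound 2 to compound 4 (0.09 log units; within the scatter). For the compounds shown here, this is the first readable step, and it shows that a much smaller open-chain group at this place leaves the number within the scatter. Compound 1 and compound 3 offer no step to either compound, and their values are limits, not numbers: the limit of > 100000 nM in this assay, at which 2 of the 4 values shown sit.

The compounds shown leave open how a plain butyl chain, a carboxylic acid or a longer amine chain at this place would read in this assay. Going by these compounds alone, also open is what the trifluoromethyl group shared by compound 2 and compound 4 contributes, with no step at that group to read.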